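Cytotoxicity notes on alkynyl triazole carboxamides, compound 3

The compounds below may be only part of what the source reports. "The series", "measured", "known", "first", "only" and "open" are said of these compounds alone.

Measured compounds:
compound 1, `NC(=O)c1nc(C#Cc2cccc(F)c2)n(COCCO)n1`: in an ADME assay on Huh-5-2 cells (Homo sapiens) for cytotoxicity (a higher number here means that more compound is tolerated, a lower number that less compound is tolerated), compound 1 gives 29 ug/mL.
compound 2, `NC(=O)c1nc(C#Cc2ccccc2F)n(COCCO)n1`: in this assay compound 2 gives > 50 ug/mL, which is a limit of the assay.

Compound 2 therefore stands only at a limit, not at a number, as recorded by the limit of > 50 ug/mL in this assay, at which 1 of the 2 values shown sits. Going by the values given here, the single measured step, an at least 1.7-fold higher number from compound 1 to compound 2 (0.23 log units; that floor lies within the scatter), moves the fluorine within the phenyl and reports only a floor. Compound 3, `NC(=O)c1nc(C#CC2(O)CCCC2)n(COCCO)n1`, differs from compound 2 by 1-hydroxycyclopentyl in place of 2-fluorophenyl on a triple-bonded carbon. Among the compounds with values here, no measured step exchanges the whole aryl, so the one step bears on this change only loosely and gives no direction. Compound 3 is expected near the same limit, estimated at 50 ug/mL with a range of 25 ug/mL to 100 ug/mL. The estimated step of a number no higher from compound 2 to compound 3 (the limit leaves the size open) is expected to stay within the scatter.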

Compound 3, half-maximal cytotoxic concentration: > 50 ug/mL
Compound 3 was reported as a limit; the forecaster's own chance of this, stated with the estimate: 60%; the middle value sits exactly at the limit.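

In this assay compound 3 gives > 50 ug/mL, which is a limit of the assay. On a triple-bonded carbon, the exchange of 3-fluorophenyl for 1-hydroxycyclopentyl gives an at least 1.7-fold higher number from compound 1 to compound 3 (0.23 log units; that floor lies within the scatter), so this first replacement of the aromatic ring by a five-membered non-aromatic ring carrying a hydroxyl shows no fall in the tolerated concentration, though the change remains within what repeated measurements could produce. The step between compound 2 and compound 3 cannot be read, and the non-aromatic ring reaches the same ceiling as 2-fluorophenyl: the limit of > 50 ug/mL in this assay, at which 2 of the 3 values shown sit.

As far as these compounds go, how far the true values of compound 2 and compound 3 lie past that limit stays open, and no order between them can be given. Also open, from the compounds shown here alone, is what an amine, a carboxylic acid or a longer open chain on the triple-bonded carbon would give in this assay.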